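Working notes: from compound 3 to compound 4

A few compounds are considered here, and "the series" means these few. Any claim that something is new, unique, unknown or untested is made for them only; others in the source may bear on it.

Measured in a functional assay (mast cells) for inhibition, with Rattus norvegicus as the target; on this read-out lower numbers stand for an effect already at smaller amounts and higher numbers for an effect only at larger amounts of compound:
- compound 1 `CC1CC/C(=N\Nc2ccc(Br)cc2)c2ncc(C(=O)O)c(=O)n21`: 2000 nM
- compound 2 `CC(=O)c1ccc(N/N=C2\CCC(C)n3c2ncc(C(=O)O)c3=O)cc1`: 8100 nM
- compound 3 `CCCCc1ccc(N/N=C2\CCC(C)n3c2ncc(C(=O)O)c3=O)cc1`: 1700 nM

Compound 3 stands at the low end of the three numbers, level with compound 1: the measured step is a 1.2-fold lower number from compound 1 to compound 3 (0.07 log units; within the scatter). The gap to the high end is a 4.8-fold lower number from compound 2 to compound 3 (0.68 log units; beyond the scatter).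

Compound 4 `CC1CC/C(=N\Nc2ccc(CC(=O)O)cc2)c2ncc(C(=O)O)c(=O)n21` carries carboxy in place of propyl on a saturated chain carbon bound to an aromatic carbon; cut one bond further out, this is butyl to carboxymethyl.

For the measured compounds named here, no measured compound holds carboxymethyl. Going by the values given here, the closest guide is acetyl, the only measured group containing oxygen, with a 4.1-fold higher number from compound 1 to compound 2 (0.61 log units; beyond the scatter). The step expected in this assay is therefore a modest rise beyond the scatter, a 3.5-fold higher number from compound 3 to compound 4 (0.55 log units; beyond the scatter). For compound 4 the estimated value is 6000 nM, with an expected range of 2000 nM to 20000 nM.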

Compound 4, half-maximal effective concentration: 3400 nM
For compound 4 the middle estimate is 1.8-fold (0.25 log units) above the measured one; the range from low to high includes it.
By their numbers in this assay, from the lowest: compounds 3, 1 and 4 (each within the scatter of the next); then compound 2.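

Both a 2.0-fold higher number from compound 3 to compound 4 (0.30 log units; within the scatter) and a 1.7-fold higher number from compound 1 to compound 4 (0.23 log units; within the scatter) in this assay lie within the scatter, so carboxymethyl reads level with butyl and bromo at this place. Oxygen in the group does not by itself give the high number of compound 2: a 2.4-fold lower number from compound 2 to compound 4 (0.38 log units; beyond the scatter) lies beyond the scatter and leaves acetyl alone at the high end.

Going by these compounds, whether an amine or a sulfonamide at this place would stay level remains open. No supporting measurement accounts for acetyl standing apart.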